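This account rests on a few compounds, and the source may have more. Where it says the series, first, only, none or still open, it means among the compounds named here.

In a functional assay on T47D cells (Homo sapiens) for antiproliferative activity, read by MTT assay, with a stated time of 48 h (on this read-out higher numbers stand for weaker inhibition and lower numbers for stronger inhibition), compound 3 `c1ccc2[nH]c(-c3nc4ccccc4[nH]3)cc2c1` gives 6200 nM. That cannot be told apart from compound 2 `Cc1cccc2[nH]c(-c3cc4ccccc4[nH]3)nc12` at 8900 nM, since the step is a 1.4-fold lower number from compound 2 to compound 3 (0.16 log units; within the scatter). Compound 1 `c1ccc(Cn2c(-c3nc4ccccc4[nH]3)cc3ccccc32)cc1` gives 21500 nM, and the step there is a 3.5-fold lower number from compound 1 to compound 3 (0.54 log units; beyond the scatter). Compound 4 `Brc1ccc2[nH]c(-c3cc4ccccc4[nH]3)nc2c1` has bromo in place of hydrogen on an aromatic carbon of compound 3: bromo in place of hydrogen on an aromatic carbon. The step with compound 1 concerns an aromatic nitrogen, so it bears little on this change. The better guide is compound 2, also changed on an aromatic carbon, at a 1.4-fold lower number from compound 2 to compound 3 (0.16 log units; within the scatter). For the measured compounds named here, no bromo compound has been measured, so no step beyond the scatter is expected in this assay. The estimated step is a 1.1-fold lower number from compound 3 to compound 4 (0.05 log units; within the scatter). For compound 4 the expected value is 5500 nM, within an estimated range of 2000 nM to 14000 nM.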

Compound 4, half-maximal inhibitory concentration: 4990 nM
For compound 4 the middle estimate is 1.1-fold (0.04 log units) above the measured one; the measured number falls inside the stated range.
By their numbers in this assay, from the lowest: compounds 4, 3 and 2 (each within the scatter of the next); then compound 1.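

The step in this assay is a 1.2-fold lower number from compound 3 to compound 4 (0.09 log units; within the scatter) and so cannot be told apart from no change, which means this aromatic carbon can carry bromo without a clear gain or loss in antiproliferative activity. For the compounds shown here, the earlier compounds carried no halogen, so this is the first sign that a bromine is accepted here. Nothing measured explains this outcome. Still open, on these data alone, is whether an amine or a carboxylic acid on this same carbon would also leave the number unchanged. As far as these compounds go, it is also open whether bromo would behave the same way on the other carbons of this ring.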